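The source may hold more compounds than are shown below. What is called first, only, known or untested is meant among the compounds shown, and "the series" means these compounds.

Measured so far in an ADME assay for pharmacokinetics, read by HPLC, in phosphate buffer, with a stated time of 72 h, at pH 7.4, tested at 250 uM; on this read-out lower numbers stand for a shorter-lived compound and higher numbers for a longer-lived compound:
Compound 1 `O=C1C=CC(=O)N1c1cc(C(F)(F)F)cc(C(F)(F)F)c1` gives < 0.017 h; this is a limit of the assay, (the limit of < 0.017 h in this assay, at which 1 of the 3 values shown sits).
Compound 2 `C#Cc1cc(C(F)(F)F)cc(C(F)(F)F)c1` gives 2.4 h.
Compound 3 `N#Cc1cc(C(F)(F)F)cc(C(F)(F)F)c1` gives > 50 h; this is a limit of the assay, (the limit of > 50 h in this assay, at which 1 of the 3 values shown sits).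

Among the compounds with values here, compound 2 therefore holds the only number among the three results; the other two are limits, one at each end. The measured steps that touch compound 2 are an at least 140-fold higher number from compound 1 to compound 2 (2.14 log units; beyond the scatter) and an at least 20-fold higher number from compound 2 to compound 3 (1.31 log units; beyond the scatter), both large; the third step, an at least 2900-fold higher number from compound 1 to compound 3 (3.46 log units; beyond the scatter), spans the whole range from one limit to the other.

Compound 4 `FC(F)(F)c1cc(C2CO2)cc(C(F)(F)F)c1` differs from compound 2 by oxiran-2-yl in place of ethynyl on an aromatic carbon. Within the data shown here, no measured step carries an oxiran-2-yl group, so the two steps through compound 2 bear on it only indirectly: each exchange of the group on the aromatic carbon of the shared core moved the half-life by a large amount, and since compound 2 sits between a lower and an upper limit, a move in either direction is open. Against that background a moderate step upward is expected, a 6.3-fold higher number from compound 2 to compound 4 (0.80 log units; beyond the scatter) in this assay, with a wide range on both sides. Compound 4 is estimated at 15 h, between 2 h and 50 h.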

Compound 4, half-life: > 50 h
Compound 4 gave a limit, no number (the forecaster's own chance of this, stated with the estimate: 30%); middle value at least 3.3-fold (0.52 log units) away from the limit.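

In this assay, oxiran-2-yl on the aromatic carbon of the shared core gives a large rise over ethynyl, an at least 20-fold higher number from compound 2 to compound 4 (1.31 log units; beyond the scatter), and over the group carried by compound 1, an at least 2900-fold higher number from compound 1 to compound 4 (3.46 log units; beyond the scatter). Nitrile in compound 3 is therefore not the only replacement for ethynyl at this position that lengthens the half-life beyond the scatter, and a non-linear group with a three-membered non-aromatic ring does so as well, while the five-membered non-aromatic ring of compound 1 stands at the opposite limit, so a ring on this carbon does not by itself go with a short half-life. Compound 4 gives a limit and not a number, and it now shares the upper end of the read-out with compound 3: the limit of > 50 h in this assay, at which 2 of the 4 values shown sit.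

The step between compound 3 and compound 4 cannot be read, as both values are limits, so no order between nitrile and oxiran-2-yl can be stated. Going by these compounds, how the half-life responds to an amine, a carboxylic acid or a longer chain on the same aromatic carbon remains open, as does how far above the limit compound 3 and compound 4 actually lie.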